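This account rests on a few compounds, and the source may have more. Where it says the series, first, only, none or still open, it means among the compounds named here.

Compound 1, with the structure `Cc1cccc2c(=O)c(-c3nn[nH]n3)c[nH]c12`, was tested in a functional assay on the whole organism (strain Sprague-Dawley) for inhibition, with Rattus norvegicus as the target; a higher number here means that more compound is needed for the effect, a lower number that less compound is needed. Its result is a limit of the assay and not a number: in this assay compound 1 gives > 10 mg/kg. Compound 2, with the structure `O=c1c(-c2nn[nH]n2)c[nH]c2c(Cl)c(Cl)ccc12`, also reaches only a limit; in this assay compound 2 gives > 10 mg/kg. Compound 3, with the structure `O=C(O)c1cnc2ccc(C(F)(F)F)cc2c1`, stands at a different limit, and in this assay compound 3 gives > 50 mg/kg. Compound 1 thus sits where two of the three measured values sit, at the limit of > 10 mg/kg in this assay, at which 2 of the 3 values shown sit, while the remaining value sits at the limit of > 50 mg/kg in this assay, at which 1 of the 3 values shown sits. Among the measured compounds shown here, no step between measured compounds can be drawn from these numbers, since none of them is a number.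

Compound 4, with the structure `O=c1c(-c2nn[nH]n2)c[nH]c2c(F)cccc12`, has not yet been measured in this assay. It differs from compound 1 in one place: fluoro in place of methyl on an aromatic carbon. Since every measured value is a limit, no direction beyond the scatter can be expected from the measured compounds, and the estimate for the step is a step that the limit leaves unreadable from compound 1 to compound 4. The value expected for compound 4 is 20 mg/kg, with a range from 5 mg/kg to 100 mg/kg, and a limit is the more likely outcome.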

Compound 4, minimum effective dose: 10 mg/kg
For compound 4 the middle estimate is 2.0-fold (0.30 log units) above the measured one; measured number inside the range.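

In this assay compound 4 is the first compound shown to give a number and not a limit, so this aromatic carbon, ortho to a fused ring, now has a readable result on one side of the change. Fluoro in place of methyl gives a number no higher from compound 1 to compound 4 (the limit leaves the size open), which shows a direction that may include no change at all, but no size. Compound 1 stays at a limit, and that limit is the common one in the set: the limit of > 10 mg/kg in this assay, at which 2 of the 4 values shown sit.

The compounds shown leave open how large the step from methyl to fluoro really is. They also leave open whether a methoxy group or a nitrile on this same carbon would give a number as fluoro does.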